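The source may hold more compounds than are shown below. What is called first, only, known or untested is meant among the compounds shown, and "the series" means these compounds.

Working notes on the series.

In a functional assay on MKN-45 cells (Homo sapiens) for inhibition, read by MTT assay (on this read-out lower numbers stand for stronger inhibition and higher numbers for weaker inhibition), compound 1 `CCOC(=O)c1c(N)sc(C(=O)Nc2ccccc2)c1-c1ccccc1` gives 8090 nM, compound 2 `CCOC(=O)c1c(NC(=O)CC#N)sc(C(=O)Nc2ccccc2)c1-c1ccccc1` gives 590 nM, and compound 3 `N#CCC(=O)Nc1sc(C(=O)Nc2ccccc2)c(-c2ccccc2)c1C#N` gives 9140 nM. Compound 2 holds the lowest number of the three, and both steps away from it are beyond the scatter: the step of a 14-fold lower number from compound 1 to compound 2 (1.14 log units; beyond the scatter) concerns the substituent on the ring nitrogen of the shared core, and the step of a 15-fold higher number from compound 2 to compound 3 (1.19 log units; beyond the scatter) concerns the ethoxycarbonyl on the shared core.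

Compound 4 `CCOC(=O)c1c(NC(=O)CC#N)sc(C(=O)Nc2ccc(Cl)cc2)c1-c1ccccc1` differs from compound 2 on the anilide ring only, (chloro in place of hydrogen on an aromatic carbon). Neither measured step touches that ring; both sit on the shared core, so they say nothing direct about the size or direction of a change at this place. With no step of this kind in hand, the working expectation is no change beyond the scatter, held with a wide range. Compound 4 is therefore expected to give about 500 nM in this assay, between 150 nM and 2000 nM. This corresponds to an expected step of a 1.2-fold lower number from compound 2 to compound 4 (0.07 log units; within the scatter).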

Compound 4, half-maximal inhibitory concentration: 390 nM
Beside the measured number, compound 4's estimate is 1.3-fold (0.11 log units) above it; low and high end bracket the measured number.
By their numbers in this assay, from the lowest: compounds 4 and 2 (each within the scatter of the next); then compounds 1 and 3 (each within the scatter of the next).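

The anilide ring now has its first step: chloro in place of hydrogen, para to a large group, gives a 1.5-fold lower number from compound 2 to compound 4 (0.18 log units; within the scatter) in this assay, so this place carries one chlorine atom with no change beyond the scatter. The two earlier steps, a 14-fold lower number from compound 1 to compound 2 (1.14 log units; beyond the scatter) and a 15-fold higher number from compound 2 to compound 3 (1.19 log units; beyond the scatter), both sit on the shared core and stand in contrast to this one. Nothing at hand accounts for the result on the anilide ring.

Still open, as far as these compounds go, is whether a different group at this place, such as an amine, a methoxy or a carboxylic acid, would move the number beyond the scatter. Equally open, from the compounds shown here alone, is whether chloro on another carbon of this ring, or on the nitrile-bearing core of compound 3, would give a step of similar size.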